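The source may hold more compounds than are shown below. What is called first, only, known or untested is meant among the compounds shown, and "the series" means these compounds.

In a functional assay on COR-L23 cells (Homo sapiens) for antiproliferative activity, read by CellTiter-Glo, with a stated time of 4 days (on this read-out lower numbers stand for stronger inhibition and higher numbers for weaker inhibition), compound 1 `O=C(/C=C/c1cccnc1)Nc1ccc(CN2C(=O)c3ccccc3C2=O)cc1` gives 2000 nM and compound 2 `C[C@H](NC(=O)CC(F)(F)F)c1ccc(NC(=O)[C@H]2C[C@@H]2c2cccnc2)cc1` gives 18 nM as the lower of the two numbers, a gap well beyond the scatter of repeat measurements. These two compounds differ in more than one place, so that gap cannot be tied to any single group. Compound 3 `C[C@H](NC(=O)c1ccc(C#N)cc1)c1ccc(NC(=O)[C@H]2C[C@@H]2c2cccnc2)cc1` is compound 2 with 4-cyanophenyl in place of 2,2,2-trifluoroethyl on a carbonyl carbon. Among the measured compounds shown here, no measured pair of compounds shows what this swap does, so nothing here points to a large move in either direction. The expected change is therefore small, an estimated 1.1-fold higher number from compound 2 to compound 3 (0.05 log units; within the scatter) that stays within the scatter of the measurement. For compound 3 the expected value in this assay is 20 nM with a likely range from 4 nM to 100 nM on this estimate.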

Compound 3, half-maximal inhibitory concentration: 19 nM
The estimate for compound 3 lay 1.1-fold (0.02 log units) above the measured number; the measured number falls inside the stated range.
By their numbers in this assay, from the lowest: compounds 2 and 3 (each within the scatter of the next); then compound 1.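

In this assay, the change on this carbonyl carbon, whose other neighbour is an amide-type nitrogen, gives a 1.1-fold higher number from compound 2 to compound 3 (0.02 log units; within the scatter). At this position, then, 2,2,2-trifluoroethyl and 4-cyanophenyl give numbers within the scatter of each other, even though they differ in size, in the aromatic ring and in hydrogen-bond acceptor count. Nothing measured here explains why these two groups match.

The compounds shown leave open whether the match extends to very different groups at this position, such as an amine or a carboxylic acid. They also do not separate the contribution of the nitrile from that of its aromatic ring, which a plain phenyl on the same carbonyl carbon could do.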